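From difluorophenyl to dichlorophenyl near the assay limit

A few compounds are considered here, and "the series" means these few. Any claim that something is new, unique, unknown or untested is made for them only; others in the source may bear on it.

In an ADME assay on MRC5 cells (Homo sapiens) for cytotoxicity, read by fluorescence and resazurin assay, with a stated time of 3 days (a lower number here means a stronger inhibitor, a higher number a weaker inhibitor), compound 1 (`Cc1cn(C2CCN(Cc3cccc(OC4CCCC4)c3)CC2)c(=O)[nH]c1=O`) gives a true number of 30300 nM on the scale. Compound 2 (`Cc1cn(C2CCN(Cc3cccc(Oc4ccc(F)c(F)c4)c3)CC2)c(=O)[nH]c1=O`) gives > 64000 nM as a limit of the assay. Going by these compounds, compound 3 (`Cc1cn(C2CCN(Cc3cccc(Oc4cc(F)cc(F)c4)c3)CC2)c(=O)[nH]c1=O`) likewise gives > 64000 nM as a limit, so its exact place is unknown.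

Compound 4 (`Cc1cn(C2CCN(Cc3cccc(Oc4ccc(Cl)c(Cl)c4)c3)CC2)c(=O)[nH]c1=O`) has 3,4-dichlorophenyl in place of 3,5-difluorophenyl on an oxygen on an aromatic ring. Going by the values given here, no measured step exchanges fluorine for chlorine, so the evidence is indirect. Replacing cyclopentyl with a difluorophenyl gave an at least 2.1-fold higher number from compound 1 to compound 2 (0.32 log units; beyond the scatter) and also an at least 2.1-fold higher number from compound 1 to compound 3 (0.32 log units; beyond the scatter) in the two cases tested. The remaining comparison is a step that the two limits leave unreadable from compound 2 to compound 3 and adds little.

Among the compounds with values here, both phenyl ethers measured so far sit at one reading, the limit of > 64000 nM in this assay, at which 2 of the 3 values shown sit, and compound 1 is the only readable value. A modest fall in the number is therefore expected, though compound 4 may also stay at the limit. The expected change is an at least 1.6-fold lower number from compound 3 to compound 4 (0.20 log units; that floor lies within the scatter) in this assay on this estimate. Compound 4 is expected to read 40000 nM with 15000 nM to 64000 nM as the estimated range.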

Compound 4, half-maximal inhibitory concentration: 6100 nM
Compound 4: the middle estimate sits 6.6-fold (0.82 log units) above what was measured, and the stated range ends above it.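

In this assay, the halogen on this ring matters a great deal: with only fluorine exchanged for chlorine, the change gives an at least 10-fold lower number from compound 2 to compound 4 (1.02 log units; beyond the scatter), and the step from the other difluorophenyl ether gives an at least 10-fold lower number from compound 3 to compound 4 (1.02 log units; beyond the scatter). Both steps are only floors because their starting compounds are limits of the assay, not numbers: the limit of > 64000 nM in this assay, at which 2 of the 4 values shown sit.

The cyclopentyl comparison also turns around, with 3,4-dichlorophenyl giving a 5.0-fold lower number from compound 1 to compound 4 (0.70 log units; beyond the scatter), whereas both difluorophenyl ethers read higher than the cyclopentyl ether, so a phenyl ring on this oxygen does not by itself raise the number.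

Going by these compounds, whether the fall is specific to chlorine remains open. A phenyl ring carrying bromine or methyl groups at the same places would help to settle this.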